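A dimethylamino change on compound 3

The source may hold more compounds than are shown below. What is called first, only, known or untested is meant among the compounds shown, and "the series" means these compounds.

Measured in a physicochemical assay for solubility, with a stated time of 24 h, tested at 30 mg/mL (a lower number here means a less soluble compound, a higher number a more soluble compound), so far:
compound 1 `O=C(CCCCCNc1c(Nc2ccccc2)c(=O)c1=O)NO` gives 2200000 nM
compound 2 `O=C(CCCCCNc1c(NC2CCCCC2)c(=O)c1=O)NO` gives 8700000 nM
compound 3 `Cc1ccc(Nc2c(NCCCCCC(=O)NO)c(=O)c2=O)cc1` gives 1800000 nM

The data show a 1.2-fold lower number from compound 1 to compound 3 (0.09 log units; within the scatter) and a 4.8-fold lower number from compound 2 to compound 3 (0.68 log units; beyond the scatter), so compound 3 stands with compound 1 at the low end of the three. Compound 4 `CN(C)c1ccc(Nc2c(NCCCCCC(=O)NO)c(=O)c2=O)cc1` carries dimethylamino in place of methyl on an aromatic carbon. The closest measured change is a 1.2-fold lower number from compound 1 to compound 3 (0.09 log units; within the scatter), which also alters a group on an aromatic carbon. The larger 4.0-fold higher number from compound 1 to compound 2 (0.60 log units; beyond the scatter) exchanges phenyl for cyclohexyl, a different kind of change. No step beyond the scatter is therefore expected in this assay. The expected step is a 1.2-fold higher number from compound 3 to compound 4 (0.09 log units; within the scatter) and it stays small. For compound 4 the estimated value is 2200000 nM with an expected range from 900000 nM to 5500000 nM as its bounds.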

Compound 4, solubility: 1400000 nM
For compound 4 the middle estimate is 1.6-fold (0.20 log units) above the measured one; the range from low to high includes it.
By their numbers in this assay, from the lowest: compounds 4, 3 and 1 (each within the scatter of the next); then compound 2.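

Going by these compounds alone, on the aromatic carbon para to a large group, the earlier compounds compared only hydrogen and methyl; in this assay, dimethylamino adds a larger group with one hydrogen-bond acceptor, giving a 1.3-fold lower number from compound 3 to compound 4 (0.11 log units; within the scatter) and a 1.6-fold lower number from compound 1 to compound 4 (0.20 log units; within the scatter). Both steps stay within the scatter, so this position has not yet separated the three groups, even with a change of three heavy atoms for one. No measurement shown here explains these numbers. The compounds shown leave open whether a carboxylic acid or a primary amine at this same aromatic carbon would give a step beyond the scatter.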